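Working notes: the step from compound 3 to compound 4

A few compounds are considered here, and "the series" means these few. Any claim that something is new, unique, unknown or untested is made for them only; others in the source may bear on it.

In an ADME assay on Raji cells (Homo sapiens) for cytotoxicity, with a stated time of 72 h (on this read-out higher numbers stand for an effect only at larger amounts of compound and lower numbers for an effect already at smaller amounts), compound 3 (`Cc1cc(NC(=O)Nc2ncccc2C)c2ccccc2n1`) gives > 25000 nM, a limit and not a number. Compound 1 (`CCc1ccc(NC(=O)Nc2cc(C)nc3ccccc23)cc1`) gives > 25000 nM, likewise a limit. Compound 3 therefore stands at the limit of > 25000 nM in this assay, at which 2 of the 3 values shown sit, without an exact place. Going by the values given here, compound 2 (`Cc1cc(NC(=O)Nc2ccc(SC(F)(F)F)cc2)c2ccccc2n1`) gives 10000 nM, the only number so far. Compound 4 (`Cc1cc(NC(=O)Nc2ccc(N)cc2)c2ccccc2n1`) carries 4-aminophenyl in place of 3-methylpyridin-2-yl on an amide-type nitrogen. Among the compounds with values here, no measured step covers this exchange. The nearest guide is an at least 2.5-fold lower number from compound 1 to compound 2 (0.39 log units; beyond the scatter), a modest change at a different place, on an aromatic carbon. A similarly modest move to a lower number is expected, so the expected step is an at least 1.3-fold lower number from compound 3 to compound 4 (0.14 log units; that floor lies within the scatter). For compound 4 the estimated value is 18000 nM, with an expected range of 7000 nM to 25000 nM.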

Compound 4, half-maximal effective concentration: > 25000 nM
Compound 4: no number, only a limit; the forecaster's own chance of this, stated with the estimate: 50%; at least 1.3-fold (0.14 log units) between middle value and limit.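

In this assay, going by these compounds alone, amino in place of (trifluoromethyl)sulfanyl on an aromatic carbon gives an at least 2.5-fold higher number from compound 2 to compound 4 (0.39 log units; beyond the scatter), so a change at this place alone can separate a compound from the only exact value. The steps from compound 3 and from compound 1 to compound 4 cannot be read, as both ends of each are limits. Compound 4 gives a limit too, and the series now gathers there: the limit of > 25000 nM in this assay, at which 3 of the 4 values shown sit.

As far as these compounds go, how 4-aminophenyl and 3-methylpyridin-2-yl compare remains open. Also open, from the compounds shown here alone, is whether a carboxylic acid or a chlorine atom on that aromatic carbon would give an exact number, as (trifluoromethyl)sulfanyl does in compound 2.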